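Acetylation of a Hydroxy Group on a Weakly Cytotoxic Core

The source may hold more compounds than are shown below. What is called first, only, known or untested is meant among the compounds shown, and "the series" means these compounds.

Three compounds have so far been examined in an ADME assay on NCI/ADR-RES cells (Homo sapiens) for cytotoxicity, read by MTT assay, with a stated time of 48 h; on this read-out lower numbers stand for stronger inhibition and higher numbers for weaker inhibition. Compound 1, `C=C1[C@H](OC(C)=O)[C@H]2[C@@H](OC(=O)c3ccccc3)[C@@H](C)C[C@]2(OC(C)=O)C(=O)[C@@H](C)/C=C/C(C)(C)C(=O)[C@H](O)[C@H]1OC(=O)c1ccccc1`, gives a value in this assay that is a limit of the assay and not a number, > 100000 nM. Compound 2, `C=C1[C@H](OC(C)=O)[C@H]2[C@@H](OC(=O)c3ccccc3)[C@](C)(O)C[C@]2(O)C(=O)[C@@H](C)/C=C/C(C)(C)C(=O)[C@H](OC(=O)C(C)C)[C@H]1OC(C)=O`, also stops at the limit of this assay, > 100000 nM. Compound 3, `C=C1[C@H](OC(C)=O)[C@H]2[C@@H](OC(=O)c3ccccc3)[C@](C)(OC(C)=O)C[C@]2(O)C(=O)[C@@H](C)/C=C/C(C)(C)C(=O)[C@H](OC(=O)C(C)C)[C@H]1OC(C)=O`, likewise reaches only the limit, > 100000 nM. How the core of compound 1 differs from the core of compound 2 is not broken down here.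

Compound 2 and compound 3 differ in a single place: acetyl in place of hydrogen on an oxygen on a saturated carbon. The step between them in this assay, a step that the two limits leave unreadable from compound 2 to compound 3, has no readable size, owing to the limit of > 100000 nM in this assay, at which 3 of the 3 values shown sit.

Compound 4, `C=C1[C@H](OC(C)=O)[C@H]2[C@@H](OC(=O)c3ccccc3)[C@@H](C)C[C@]2(OC(C)=O)C(=O)[C@@H](C)/C=C/C(C)(C)C(=O)[C@H](OC(C)=O)[C@H]1OC(=O)c1ccccc1`, has not yet been measured. It stands to compound 1 exactly as compound 3 stands to compound 2, and the change is the same: acetyl in place of hydrogen on an oxygen on a saturated carbon. Among the compounds shown this change occurs twice, and the one measured instance yields nothing that can be read.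

The expected step from compound 1 to compound 4 in this assay is a step that the limit leaves unreadable from compound 1 to compound 4, resting on compound 1 sitting at > 100000 nM and on the unreadable a step that the two limits leave unreadable from compound 2 to compound 3 between two limits. Compound 4 is therefore estimated at 150000 nM, most probably reported again only as a limit. The expected range for compound 4 runs from 40000 nM to 600000 nM.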

Compound 4, half-maximal inhibitory concentration: > 100000 nM
Compound 4: only a limit was reported; the forecaster's own chance of this, stated with the estimate: 85%; the middle value lies beyond the limit too.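

In this assay compound 4 gives > 100000 nM, which is a limit of the assay and not a number. No step from compound 1 to compound 4 can therefore be read, because both compounds stop at that limit: the limit of > 100000 nM in this assay, at which 4 of the 4 values shown sit.

The compounds shown leave open whether the change from hydroxy to acetoxy alters cytotoxicity at all, in either direction, on the core of compound 1 or the core of compound 2.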